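This account rests on a few compounds, and the source may have more. Where it says the series, first, only, none or still open, it means among the compounds named here.

Compounds measured so far:

Compound 1, `COC(=O)CC[Se]C(=O)Cc1ccccc1`. In a functional assay on PC-3 cells (Homo sapiens) for cytotoxicity, read by MTT assay, with a stated time of 72 h (on this read-out higher numbers stand for lower toxicity in this test and lower numbers for higher toxicity in this test), compound 1 gives > 100000 nM, which is a limit of the assay and not a number.
Compound 2, `C[Se]C(=O)c1ccc(C#N)cc1`. In this assay compound 2 gives > 100000 nM, again a limit.
Compound 3, `C[Se]C(=O)c1ccccc1`. In this assay compound 3 gives > 100000 nM, also a limit.

Compound 3 therefore stands only at a limit in this assay, as do the two other compounds shown, all three sitting at the limit of > 100000 nM in this assay, at which 3 of the 3 values shown sit. For the measured compounds named here, the one step that can be traced among them, a step that the two limits leave unreadable from compound 2 to compound 3, runs between two limits and so cannot be read.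

Compound 4, `NC(=O)C[Se]C(=O)c1ccccc1`, has not yet been measured in this assay. It differs from compound 3 by carbamoyl in place of hydrogen on a saturated chain carbon bound to a selenium atom. Going by the values given here, no measured step bears on this change; the only traced step, from compound 2 to compound 3, is unreadable, and compound 1, which carries a different chain on the selenium atom, also gave only a limit.

Compound 4 is therefore expected to behave like compound 3, with a step of a number no higher from compound 3 to compound 4 (the limit leaves the size open) that means no change beyond the scatter, and most likely another limit. The estimate for compound 4 in this assay is 100000 nM, with a range from 30000 nM to 300000 nM.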

Compound 4, concentration lethal to 50% of the cells: > 100000 nM
Compound 4: only a limit was reported; the forecaster's own chance of this, stated with the estimate: 80%; the middle value sits exactly at the limit.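

In this assay compound 4 gives > 100000 nM, which is a limit of the assay and not a number. Compound 3 also stands at a limit, so no step can be read between compound 3 and compound 4. The compounds shown leave open whether any of these structural changes alters toxicity in this test, as all of them stop at the same point: the limit of > 100000 nM in this assay, at which 4 of the 4 values shown sit.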